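Notes on the pyrrolidine and methylpiperazine pair

The source may report more compounds than this note shows. Statements on the series, on what has been measured and on what is new or still open speak of the compounds shown alone.

compound 1 `O=C(N/N=C/c1cccn1CCCN1CCCC1)Nc1ccc(Oc2ccnc3[nH]ccc23)c(F)c1` gives 4580 nM
compound 2 `CN1CCN(CCCn2cccc2/C=N/NC(=O)Nc2ccc(Oc3ccnc4[nH]ccc34)cc2)CC1` gives 4280 nM

In a functional assay on MCF7 cells (Homo sapiens) for antiproliferative activity, read by MTT assay, with a stated time of 72 h (on this read-out lower numbers stand for stronger inhibition and higher numbers for weaker inhibition), compound 2 gives 4280 nM, within the scatter of compound 1 at 4580 nM, so the two measured numbers do not separate. Compound 3 `O=C(N/N=C/c1cccn1CCCN1CCCC1)Nc1ccc(Oc2ccnc3[nH]ccc23)cc1` is still unmeasured and follows from compound 2 through one change: pyrrolidin-1-yl in place of 4-methylpiperazin-1-yl on a saturated chain carbon, three bonds along the chain from an aromatic nitrogen. Among the measured compounds shown here, no measured step isolates this change, so the expectation rests on the two values alone. Compound 1, which also carries 3-(pyrrolidin-1-yl)propyl, gives 4580 nM, and compound 2, with 3-(4-methylpiperazin-1-yl)propyl, gives 4280 nM. No step beyond the scatter is therefore expected in this assay, and no direction is favoured. The expected change is a 1.0-fold lower number from compound 2 to compound 3 (0.01 log units; within the scatter). For compound 3 the estimated value is 4200 nM, with an expected range of 1900 nM to 9000 nM.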

Compound 3, half-maximal inhibitory concentration: 4530 nM
Compound 3: the middle estimate sits 1.1-fold (0.03 log units) below what was measured, and the stated range covers the measured number.
By their numbers in this assay, from the lowest: compounds 2, 3 and 1 (each within the scatter of the next).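

Pyrrolidin-1-yl in place of 4-methylpiperazin-1-yl on a saturated chain carbon, three bonds along the chain from an aromatic nitrogen, now stands as a single change: in this assay the step is a 1.1-fold higher number from compound 2 to compound 3 (0.02 log units; within the scatter) and does not separate the two compounds. Hydrogen in place of fluoro on an aromatic carbon, a second difference between compound 1 and compound 2, is now isolated too, and a 1.0-fold lower number from compound 1 to compound 3 (0.00 log units; within the scatter) likewise shows no separation. No supporting evidence bears on these results.

On these data alone, whether a morpholine or a dimethylamino group in place of these rings, or a longer chain such as 4-(pyrrolidin-1-yl)butyl, would also leave the number within the scatter remains open. The same question stands for chloro or methoxy in place of fluoro on that aromatic carbon.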